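Swapping Bromo for Formyl on a Fused Core

The compounds below may be only part of what the source reports. "The series", "measured", "known", "first", "only" and "open" are said of these compounds alone.

Three compounds share a core carrying a chlorobenzyl arm, and all were tested in an ADME assay on CCRF-CEM cells (Homo sapiens) for cytotoxicity, with a stated time of 72 h; on this read-out higher numbers stand for weaker inhibition and lower numbers for stronger inhibition. Compound 1 `O=c1oc2ccccc2cc1-c1cn2nc(Cc3ccc(Cl)cc3)sc2n1` gives only a limit of the assay, > 10000 nM. Compound 2 `COc1ccc(-c2nc3sc(Cc4ccc(Cl)cc4)nn3c2Br)cc1` gives 58000 nM. Compound 3 `O=c1oc2ccccc2cc1-c1nc2sc(Cc3ccc(Cl)cc3)nn2c1Br` gives 3700 nM, the lowest of the two numbers, with compound 2 the nearest and that gap beyond the scatter. Among the measured compounds shown here, the only measured step between two structures differing in one place is an at least 2.7-fold lower number from compound 1 to compound 3 (0.43 log units; beyond the scatter), so placing bromo on the aromatic carbon brought the number down by at least a modest amount. Compound 4 `O=Cc1c(-c2cc3ccccc3oc2=O)nc2sc(Cc3ccc(Cl)cc3)nn12` has not yet been measured; it differs from compound 3 in one place: formyl in place of bromo on an aromatic carbon. For the measured compounds named here, this change removes the bromo that distinguished compound 3 from compound 1, while the entering formyl has no measured counterpart here, so its own effect is unknown. Because the step of an at least 2.7-fold lower number from compound 1 to compound 3 (0.43 log units; beyond the scatter) showed the bromo mattering, compound 4 is expected to show a 2.4-fold higher number from compound 3 to compound 4 (0.39 log units; beyond the scatter). Compound 4 is expected to give 9000 nM, with a plausible range from 2500 nM to 35000 nM.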

Compound 4, half-maximal inhibitory concentration: 750 nM
Estimate against measurement, compound 4: 12-fold (1.08 log units) above; the measured number lies below the stated range.
By their numbers in this assay, from the lowest: compound 4; then compound 3; then compound 2.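

In this assay, among the compounds shown here, bromo is not the only group at this carbon that goes with a lower number: formyl in its place gives a 4.9-fold lower number from compound 3 to compound 4 (0.69 log units; beyond the scatter). Set against the plain hydrogen at the same carbon, formyl gives an at least 13-fold lower number from compound 1 to compound 4 (1.12 log units; beyond the scatter), so both groups tested here go with lower numbers than hydrogen, and formyl goes lowest. As far as these compounds go, the true size of that second step stays unknown, since compound 1 gives only a limit of the assay: the limit of > 10000 nM in this assay, at which 1 of the 4 values shown sits.

From the compounds shown here alone, whether a carboxylic acid, an amine or a longer chain on this carbon would bring the number lower still remains open. For the compounds shown here, also open is whether formyl would give a similar step with the large group that compound 2 carries in place of the one shared by compound 3 and compound 4.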